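This account rests on a few compounds, and the source may have more. Where it says the series, first, only, none or still open, it means among the compounds named here.

In a functional assay on QGY-7703 cells (Homo sapiens) for cytotoxicity, read by MTT assay, with a stated time of 24 h (a higher number here means a weaker inhibitor, a lower number a stronger inhibitor), compound 1 `COc1cc(/C=C2\CN(S(=O)(=O)c3ccc(F)cc3)C/C(=C\c3cc(OC)c(OC)c(OC)c3)C2=O)cc(OC)c1OC` gives 2220 nM and compound 2 `COc1cc(/C=C2\CN(S(=O)(=O)c3ccc(NC(C)=O)cc3)C/C(=C\c3cc(OC)c(OC)c(OC)c3)C2=O)cc(OC)c1OC` gives 1900 nM while compound 3 `COc1cc(/C=C2\CN(S(=O)(=O)c3ccc(F)cc3)C/C(=C\c3ccccc3F)C2=O)cc(OC)c1` gives 14000 nM as a clearly higher number. Compound 2 thus sits level with compound 1 at the low end of these numbers. Compound 4 `COc1cc(/C=C2\CN(S(=O)(=O)c3ccc(NC(C)=O)cc3)C/C(=C\c3ccc(C#N)cc3)C2=O)cc(OC)c1OC` departs from compound 2 as follows: 4-cyanophenyl in place of 3,4,5-trimethoxyphenyl on a double-bonded chain carbon bound to a double-bonded ring carbon. Within the data shown here, the one measured single-place step is a 1.2-fold lower number from compound 1 to compound 2 (0.07 log units; within the scatter) for acetamido in place of fluoro on an aromatic carbon, and it concerns another place. Among the measured compounds shown here, no measured step covers this change, so the guide is weak. A higher number is expected, with the expected step being a 2.1-fold higher number from compound 2 to compound 4 (0.32 log units; beyond the scatter) in this assay and compound 3 at 14000 nM as a loose upper guide. For compound 4 the estimated value is 4000 nM (expected range 1500 nM to 12000 nM).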

Compound 4, half-maximal inhibitory concentration: 1890 nM
For compound 4 the middle estimate is 2.1-fold (0.33 log units) above the measured one, and the stated range covers the measured number.
By their numbers in this assay, from the lowest: compounds 4, 2 and 1 (each within the scatter of the next); then compound 3.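

In this assay, the 3,4,5-trimethoxyphenyl at this place on a double-bonded chain carbon bound to a double-bonded ring carbon can give way to 4-cyanophenyl with no change beyond the scatter: a 1.0-fold lower number from compound 2 to compound 4 (0.00 log units; within the scatter). The entering group has fewer heavy atoms and 1 hydrogen-bond acceptor against 3, so the full trimethoxy pattern is not needed here in the acetamido series. Nothing at hand accounts for this level result.

As far as these compounds go, whether an amine or a carboxylic acid at this place would also leave the number level remains open. So does whether the same exchange holds with fluoro in place of acetamido.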